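Side-chain homologation on two cores

The source may hold more compounds than are shown below. What is called first, only, known or untested is meant among the compounds shown, and "the series" means these compounds.

In an assay on cell membranes for displacement of a labelled ligand from Sigma non-opioid intracellular receptor 1 (Rattus norvegicus) (a lower number here means a stronger inhibitor, a higher number a weaker inhibitor), compound 1 `CCC(=O)c1ccc2c(c1)sc(=O)n2CCCCN1CCCCCC1` gives 10.3 nM and compound 2 `CCCC(=O)c1ccc2c(c1)sc(=O)n2CCCCN1CCCCCC1` gives 4.8 nM. The difference between them is methyl in place of hydrogen on a saturated chain carbon, two bonds along the chain from a carbonyl carbon, and a 2.1-fold lower number from compound 1 to compound 2 (0.33 log units; beyond the scatter). Compound 3 `CCCc1ccc2c(c1)sc(=O)n2CCCN1CCCCCC1` gives 1.4 nM in this assay; how its core differs from the core of compound 1 is not broken down here. Compound 4 `CCCCc1ccc2c(c1)sc(=O)n2CCCN1CCCCCC1` has not yet been measured. It differs from compound 3 by methyl in place of hydrogen on a saturated chain carbon, three bonds along the chain from an aromatic carbon. This is the same kind of change as that from compound 1 to compound 2, but not the same: the place in the earlier pair is two bonds along the chain from a carbonyl carbon, whereas here it is three bonds along the chain from an aromatic carbon. For compound 4 a step of similar size is expected, a 1.6-fold lower number from compound 3 to compound 4 (0.19 log units; within the scatter), resting on the single earlier case a 2.1-fold lower number from compound 1 to compound 2 (0.33 log units; beyond the scatter) with some allowance for the different place. Compound 4 is therefore estimated at 0.9 nM, between 0.4 nM and 2.5 nM.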

Compound 4, inhibition constant: 2.2 nM
Estimate against measurement, compound 4: 2.4-fold (0.39 log units) below, and the stated range covers the measured number.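

In this assay the same added methyl does not carry over with the same result from one core to the other: the same change on two cores in this assay, a 2.1-fold lower number (0.33 log units; beyond the scatter) from compound 1 to compound 2 and a 1.6-fold higher number (0.20 log units; within the scatter) from compound 3 to compound 4, 3.4-fold (0.53 log units) apart, beyond the scatter of two such steps
Taken alone, the propyl to butyl change gives a 1.6-fold higher number from compound 3 to compound 4 (0.20 log units; within the scatter), which cannot be told from repeat measurement. Only two pairs are shown, and they differ in both core and place, two bonds along the chain from a carbonyl carbon in one and three bonds along the chain from an aromatic carbon in the other, leaving it unresolved which of these goes with the gap and giving no rule for other cores.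

As far as these compounds go, a longer chain such as pentyl and a branched chain such as isobutyl remain open on both cores. Also open, from the compounds shown here alone, is whether a carbonyl-bearing side chain would give the same step on the core of compound 3.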